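The source may report more compounds than this note shows. Statements on the series, on what has been measured and on what is new or still open speak of the compounds shown alone.

Compound 1 `O=c1nc(-c2ccccc2)c2cc(-c3ccccc3F)ccc2[nH]1` gives 55800 nM in an ADME assay on L6 cells (Rattus norvegicus) for cytotoxicity, read by fluorescence and resazurin assay, with a stated time of 72 h; on this read-out higher numbers stand for an effect only at larger amounts of compound and lower numbers for an effect already at smaller amounts.
Compound 2 `O=c1nc(-c2ccccc2)c2cc(-c3ccc(F)cc3)ccc2[nH]1` gives 50000 nM in this assay.

Among the measured compounds shown here, compound 2 stands within the scatter of compound 1, the only other compound measured; the step of a 1.1-fold lower number from compound 1 to compound 2 (0.05 log units; within the scatter) shows as much. Compound 3 `O=c1nc(-c2ccccc2)c2cc(N3CCNCC3)ccc2[nH]1` differs from compound 2 by piperazin-1-yl in place of 4-fluorophenyl on an aromatic carbon. For the measured compounds named here, no measured step bears on this change: the one known step only puts 4-fluorophenyl in place of 2-fluorophenyl and stays within the scatter. With both measured numbers close together, compound 3 is expected to stay near them, so the estimated step of a 1.2-fold higher number from compound 2 to compound 3 (0.08 log units; within the scatter) is small. Compound 3 is therefore estimated at 60000 nM, with a range from 25000 nM to 150000 nM.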

Compound 3, half-maximal effective concentration: > 25000 nM
Compound 3: no number, only a limit; the forecaster's own chance of this, stated with the estimate: 25%; the middle value does not contradict the limit.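

Among the compounds shown here, compound 3 gives only a limit, > 25000 nM, not a number, so no step from compound 1 or compound 2 to it can be read. On these data alone, whether piperazin-1-yl in place of either fluorophenyl group changes the number in this assay stays open.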